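Moving the Chlorine on the Carbonyl Group

The compounds below may be only part of what the source reports. "The series", "measured", "known", "first", "only" and "open" are said of these compounds alone.

In a functional assay on ACHN cells (Homo sapiens) for cytotoxicity, read by sulforhodamine B assay, with a stated time of 72 h (a lower number here means a stronger inhibitor of growth, a higher number a weaker inhibitor of growth), compound 1 `CCC(=O)N1c2ccccc2CCC1C(=O)Nc1ccccc1C(F)(F)F` gives > 80000 nM, which is a limit of the assay and not a number. Within the data shown here, compound 2 `O=C(Nc1ccccc1C(F)(F)F)C1CCc2ccccc2N1C(=O)c1ccc(Cl)cc1` gives 824 nM, the only exact number so far. Compound 3 `O=C(Nc1ccccc1C(F)(F)F)C1CCc2ccccc2N1C(=O)c1ccccc1Cl` has 2-chlorophenyl in place of 4-chlorophenyl on a carbonyl carbon. Among the measured compounds shown here, the only measured step, an at least 97-fold lower number from compound 1 to compound 2 (1.98 log units; beyond the scatter), was large and put 4-chlorophenyl in place of ethyl on that carbon, but it does not show what moving the chlorine does. A modest weakening is therefore expected, a 1.8-fold higher number from compound 2 to compound 3 (0.26 log units; within the scatter). Compound 3 is estimated at 1500 nM, with an expected range of 400 nM to 8000 nM.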

Compound 3, concentration for 50% growth inhibition: 3900 nM
Estimate against measurement, compound 3: 2.6-fold (0.41 log units) below; low and high end bracket the measured number.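

In this assay the place of the chlorine counts, not just its presence: 2-chlorophenyl in place of 4-chlorophenyl brings a 4.7-fold higher number from compound 2 to compound 3 (0.68 log units; beyond the scatter) and so gives a weaker inhibitor of growth. Even so, 2-chlorophenyl still beats ethyl on this carbonyl carbon, with an at least 20-fold lower number from compound 1 to compound 3 (1.31 log units; beyond the scatter) still standing. That step is only a bound, as compound 1 gives a limit of the assay and not a number: the limit of > 80000 nM in this assay, at which 1 of the 3 values shown sits. Still open, as far as these compounds go, is how a bromine or a methoxy group in place of the chlorine, or a phenyl ring with no chlorine at all, would compare.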